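Swapping the aryl group on a non-toxic compound

The source may report more compounds than this note shows. Statements on the series, on what has been measured and on what is new or still open speak of the compounds shown alone.

Values in an ADME assay on MT2 cells (Homo sapiens) for cytotoxicity, read by XTT assay, with a stated time of 4 days; on this read-out lower numbers stand for higher toxicity in this test and higher numbers for lower toxicity in this test
- compound 1 `Cc1nc(C(NC(=O)C(=O)Nc2ccc(Cl)cc2)C2CCNCC2)sc1CCO` gives > 78500 nM (a limit)
- compound 2 `Cc1nc(C(NC(=O)C(=O)Nc2ccc(Cl)cc2)C2CCCCN2)sc1CO` gives > 108000 nM (a limit)
- compound 3 `CC(=O)N1CCCCC1C(NC(=O)C(=O)Nc1ccc(Cl)cc1)c1nc(C)c(CCO)s1` gives > 84000 nM (a limit)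

Compound 2 stands at > 108000 nM and this is a limit, not a number. Compound 4 `Cc1nc(C(NC(=O)C(=O)Nc2ccc(F)cc2F)C2CCCCN2)sc1CO` differs from compound 2 by one change 2,4-difluorophenyl in place of 4-chlorophenyl on an amide-type nitrogen with 2,4-difluorophenyl in place of 4-chlorophenyl on an amide-type nitrogen. Among the measured compounds shown here, the only measured step is a step that the two limits leave unreadable from compound 1 to compound 3 and it lies elsewhere in the molecule, so no measured step bears on this change. The expectation therefore rests on compound 2 at > 108000 nM alone, and no change beyond the usual scatter is expected in this assay here. The estimated step is an at least 1.0-fold lower number from compound 2 to compound 4 (0.03 log units; that floor lies within the scatter) in size. For compound 4 the estimated value is 100000 nM with an expected range from 50000 nM to 140000 nM in this estimate.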

Compound 4, half-maximal cytotoxic concentration: > 110000 nM
Compound 4: no number, only a limit (the forecaster's own chance of this, stated with the estimate: 80%); middle value at least 1.1-fold (0.04 log units) away from the limit.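

Compound 2 and compound 4 both give only limits, not numbers, and no step can be read between them. The compounds shown leave open at what concentration any of them becomes toxic to these cells.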